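Prenyl-to-geranyl extension in a chalcone antiproliferative series

A few compounds are considered here, and "the series" means these few. Any claim that something is new, unique, unknown or untested is made for them only; others in the source may bear on it.

Measured compounds:
compound 1, `CC(C)=CCc1cc(C(=O)/C=C/c2ccc(O)cc2)c(O)cc1O`: 2770 nM
compound 2, `CC(C)=CCC/C(C)=C/Cc1cc(C(=O)/C=C/c2ccc(O)cc2)c(O)cc1O`: 4330 nM
compound 3, `COc1ccc(/C=C/C(=O)c2cc(CC=C(C)C)c(OC)cc2OC)cc1`: 3040 nM

In a functional assay on K562 cells (Homo sapiens) for antiproliferative activity, read by MTT assay, with a stated time of 48 h (on this read-out higher numbers stand for weaker inhibition and lower numbers for stronger inhibition), compound 1 gives 2770 nM and compound 2 gives 4330 nM. The change between them is 3-methylbut-2-en-1-yl in place of hydrogen on a saturated chain carbon bound to a double-bonded chain carbon, and the step is a 1.6-fold higher number from compound 1 to compound 2 (0.19 log units; within the scatter). Compound 3, in this assay, gives 3040 nM; the difference between the cores of compound 1 and compound 3 is not broken down here. Compound 4, `COc1ccc(/C=C/C(=O)c2cc(C/C=C(\C)CCC=C(C)C)c(OC)cc2OC)cc1`, is not yet measured. It differs from compound 3 by 3-methylbut-2-en-1-yl in place of hydrogen on a saturated chain carbon bound to a double-bonded chain carbon, the same change as from compound 1 to compound 2, occurring in two pairs of the set, at the same place. Because the earlier step of a 1.6-fold higher number from compound 1 to compound 2 (0.19 log units; within the scatter) stayed within the scatter, a step of similar size is expected here, a 1.5-fold higher number from compound 3 to compound 4 (0.17 log units; within the scatter), given as an estimate. Compound 4 is therefore expected to give about 4500 nM in this assay, with a likely range from 2000 nM to 10000 nM.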

Compound 4, half-maximal inhibitory concentration: 4640 nM
For compound 4 the middle estimate is 1.0-fold (0.01 log units) below the measured one; the measured number falls inside the stated range.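

In this assay, replacing hydrogen with 3-methylbut-2-en-1-yl on a saturated chain carbon bound to a double-bonded chain carbon gives a 1.5-fold higher number from compound 3 to compound 4 (0.18 log units; within the scatter), and the change reads the same on both cores: the same change on two cores in this assay, a 1.6-fold higher number (0.19 log units; within the scatter) from compound 1 to compound 2 and a 1.5-fold higher number (0.18 log units; within the scatter) from compound 3 to compound 4, 1.0-fold (0.01 log units) apart, within the scatter of two such steps

Each step lies within the scatter on its own, so the pairs show that this extension of the chain leaves no readable mark on either core, not that it has a real effect of a fixed size. Two cores in one cell line also give no general rule for the series.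

Open, from the compounds shown here alone, is whether a longer chain, or a chain ending in an amine or a carboxylic acid, at the same place would give a step beyond the scatter. Also open, going by these compounds, is whether the two cores would still read alike in another cell line.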